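The source may hold more compounds than are shown below. What is called first, only, known or untested is meant among the compounds shown, and "the series" means these compounds.

Measured compounds:
- compound 1, `O=C(Nc1ccc(Br)cc1)Nc1ccc(Nc2ncnc3c2OCCN3)cc1`: 2220 nM
- compound 2, `COc1cccc(NC(=O)Nc2ccc(Nc3ncnc4c3OCCN4)cc2)c1`: 6810 nM

Compound 2 stands at the highest of the two numbers in an assay on isolated protein for inhibition of proto-oncogene tyrosine-protein kinase receptor Ret (Homo sapiens), read by 33P incorporation, with stated times of 15 min and 40 min; on this read-out higher numbers stand for weaker inhibition and lower numbers for stronger inhibition; its nearest neighbour is compound 1, which differs from it only in the aryl group on the urea-type nitrogen. Among the measured compounds shown here, that single step, a 3.1-fold higher number from compound 1 to compound 2 (0.49 log units; beyond the scatter), is the only measured step here, and it concerns exactly the position that changes in the next compound.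

Compound 3, `Cc1ccc(F)c(NC(=O)Nc2ccc(Nc3ncnc4c3OCCN4)cc2)c1`, has not yet been measured in this assay. It differs from compound 2 in one place: 2-fluoro-5-methylphenyl in place of 3-methoxyphenyl on an amide-type nitrogen. So the aryl group on the urea nitrogen is exchanged once more, as it was from compound 1 to compound 2. That earlier exchange moved the number by a modest amount. Since a similar exchange at the same place gave a modest shift, a shift of comparable size is expected here, and because compound 1 with its 4-bromophenyl gave 2220 nM, a move back toward lower numbers seems somewhat more likely than a further rise. Compound 3 is therefore estimated at 3500 nM, within a range of 1200 nM to 10000 nM, a step of a 1.9-fold lower number from compound 2 to compound 3 (0.29 log units; within the scatter).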

Compound 3, half-maximal inhibitory concentration: 1470 nM
Estimate against measurement, compound 3: 2.4-fold (0.38 log units) above; low and high end bracket the measured number.
By their numbers in this assay, from the lowest: compounds 3 and 1 (each within the scatter of the next); then compound 2.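

In this assay the exchange of 3-methoxyphenyl for 2-fluoro-5-methylphenyl on the amide-type nitrogen gives a 4.6-fold lower number from compound 2 to compound 3 (0.67 log units; beyond the scatter) and so shows that a change at this position can lower the number as well as raise it. The comparison of the two remaining groups gives a 1.5-fold lower number from compound 1 to compound 3 (0.18 log units; within the scatter) and means that 4-bromophenyl and 2-fluoro-5-methylphenyl cannot be told apart here, although their rings are decorated quite differently, while compound 2 stands alone as the weakest of the three, with its steps to both others beyond the scatter. Nothing available explains why the 3-methoxyphenyl group sits apart from the other two.

Compound 3 carries a fluorine and a methyl on one ring, so the compounds shown cannot say what each contributes alone, and a phenyl ring bearing only one of them, or an unsubstituted phenyl, would be needed to separate the two. As far as these compounds go, it also remains open how this position responds to groups of a different kind, such as a ring bearing an amine or a carboxylic acid, or a cyclohexyl in place of the aromatic ring.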